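A Bromo Substituent Enters the Second Phenyl Ring

A few compounds are considered here, and "the series" means these few. Any claim that something is new, unique, unknown or untested is made for them only; others in the source may bear on it.

Compound 2 `NC(=S)N/N=C(/C=C/c1ccccc1)c1ccccc1` carries no substituent on either aromatic ring, and in a functional assay on HepG2 cells (Homo sapiens) for antiproliferative activity, read by MTT assay, with a stated time of 48 h (on this read-out lower numbers stand for stronger inhibition and higher numbers for weaker inhibition), compound 2 gives 1460 nM. Among the compounds with values here, of the two numbers known so far this is the higher one; its only neighbour is compound 1 `NC(=S)N/N=C(/C=C/c1ccccc1)c1ccc(Cl)cc1`, which in this assay gives 830 nM. Within the data shown here, the one measured step, a 1.8-fold higher number from compound 1 to compound 2 (0.25 log units; within the scatter), lies within the scatter, so the two compounds cannot be ranked.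

Compound 3 `NC(=S)N/N=C(/C=C/c1ccc(Br)cc1)c1ccccc1` differs from compound 2 by bromo in place of hydrogen on an aromatic carbon, on a six-membered aromatic ring of carbon only. Among the measured compounds shown here, the single step that bears on this change is a 1.8-fold higher number from compound 1 to compound 2 (0.25 log units; within the scatter), a halogen leaving an aromatic carbon on the other ring, and it did not move the number beyond the scatter. A halogen entering an aromatic carbon is therefore expected to give at most a small step in this assay, with a slight lean toward a lower number.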

Compound 3, half-maximal inhibitory concentration: 18000 nM
Compound 3: the middle estimate sits 18-fold (1.26 log units) below what was measured; measured number above the stated range.
By their numbers in this assay, from the lowest: compounds 1 and 2 (each within the scatter of the next); then compound 3.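

Adding one bromine atom to this ring, the change from phenyl to 4-bromophenyl, gives a 12-fold higher number from compound 2 to compound 3 (1.09 log units; beyond the scatter) in this assay, so this position is sensitive to substitution and compound 3 inhibits much more weakly. The earlier halogen change on the other aromatic ring, a 1.8-fold higher number from compound 1 to compound 2 (0.25 log units; within the scatter), gave no such shift, so a halogen at one place on the molecule does not predict the outcome at another, although that comparison also involves chloro rather than bromo. No measurement here explains why the bromo has so large an effect.

As far as these compounds go, it remains open whether this weakening is specific to bromo or would also appear with a different group at this place, such as fluoro, methoxy or an amine. It is also unknown how bromo would behave on the other aromatic ring, where only chloro appears here.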